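This account rests on a few compounds, and the source may have more. Where it says the series, first, only, none or still open, it means among the compounds named here.

Measured compounds in a functional assay on HT-29 cells (Homo sapiens) for antiproliferative activity, read by sulforhodamine B assay, with a stated time of 48 h; a lower number here means a stronger inhibitor, a higher number a weaker inhibitor:
- compound 1 `COc1ccc(NS(=O)(=O)c2ccc(N3CCNC3=O)cc2)cc1` gives 800 nM
- compound 2 `O=C1NCCN1c1ccc(S(=O)(=O)Nc2ccc(OC(F)F)cc2)cc1` gives 650 nM
- compound 3 `O=C1NCCN1c1ccc(S(=O)(=O)Nc2ccc(C3CCCCC3)cc2)cc1` gives > 1000 nM, which is a limit of the assay, not a number

Among the two numbers, compound 1 stands highest, and the step of a 1.2-fold lower number from compound 1 to compound 2 (0.09 log units; within the scatter) lies within the scatter. For compound 3 only the limit of > 1000 nM in this assay, at which 1 of the 3 values shown sits, is known.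

Compound 4 `COc1ccccc1NS(=O)(=O)c1ccc(N2CCNC2=O)cc1` differs from compound 1 in one place: 2-methoxyphenyl in place of 4-methoxyphenyl on a sulfonamide nitrogen. The measured steps of a 1.2-fold lower number from compound 1 to compound 2 (0.09 log units; within the scatter) and an at least 1.2-fold higher number from compound 1 to compound 3 (0.09 log units; that floor lies within the scatter) exchange the group itself rather than moving it, so neither speaks directly to this change, and both stay within the scatter. No step beyond the scatter is therefore expected; compound 4 is estimated at 1000 nM, between 400 nM and 2500 nM, which means an expected step of a 1.3-fold higher number from compound 1 to compound 4 (0.10 log units; within the scatter).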

Compound 4, half-maximal inhibitory concentration: 550 nM
Compound 4: the middle estimate sits 1.8-fold (0.26 log units) above what was measured; measured number inside the range.
By their numbers in this assay, from the lowest: compounds 4, 2 and 1 (each within the scatter of the next). At a limit, above all of these: compound 3.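

Among the compounds shown here, compound 4 keeps the same atoms as compound 1 and only moves the methoxy group, with 2-methoxyphenyl in place of 4-methoxyphenyl on the sulfonamide nitrogen, whereas the earlier steps exchanged the group itself. In this assay this gives a 1.5-fold lower number from compound 1 to compound 4 (0.16 log units; within the scatter), so this move on the ring produces no step beyond the scatter. Nothing measured here offers a reason for this result.

The compounds shown leave open whether an amine or a carboxylic acid on this ring would give a step beyond the scatter.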